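Compound 3 to compound 4: a dimethoxyphenyl swap

This account rests on a few compounds, and the source may have more. Where it says the series, first, only, none or still open, it means among the compounds named here.

- Compound 1 `COC(=O)/C(=C\c1ccc(OC(=O)c2ccccc2)cc1)Sc1ccnc2cc(Cl)ccc12` gives > 100000 nM as a limit, not a number
- Compound 2 `COC(=O)/C(=C\c1ccc(OC(=O)c2ccc(OC)cc2)cc1)Sc1ccnc2cc(Cl)ccc12` gives 63500 nM as a measured number
- Compound 3 `COC(=O)/C(=C\c1ccc(OC(=O)c2ccccc2OC)cc1)Sc1ccnc2cc(Cl)ccc12` gives > 100000 nM as a limit, not a number

In an ADME assay on cells (Lymphocyte, Homo sapiens) for cytotoxicity, read by MTT assay, with a stated time of 48 h (on this read-out higher numbers stand for weaker inhibition and lower numbers for stronger inhibition), compound 3 stands at the limit of > 100000 nM in this assay, at which 2 of the 3 values shown sit, and has no exact number. Compound 4 `COC(=O)/C(=C\c1ccc(OC(=O)c2cc(OC)cc(OC)c2)cc1)Sc1ccnc2cc(Cl)ccc12` brings (3,5-dimethoxyphenyl in place of 2-methoxyphenyl on a carbonyl carbon), with 3,5-dimethoxyphenyl in place of 2-methoxyphenyl on a carbonyl carbon. Among the compounds with values here, two measured steps bear on this: an at least 1.5-fold lower number from compound 1 to compound 2 (0.19 log units; that floor lies within the scatter) and an at least 1.5-fold higher number from compound 2 to compound 3 (0.19 log units; that floor lies within the scatter). Only compound 2 gave a number, 63500 nM, so these steps offer weak guidance. The expected step is an at least 1.1-fold lower number from compound 3 to compound 4 (0.07 log units; that floor lies within the scatter), probably no larger than the scatter. For compound 4 the estimated value is 85000 nM, with an expected range from 40000 nM to 180000 nM.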

Compound 4, half-maximal inhibitory concentration: 84100 nM
Estimate against measurement, compound 4: 1.0-fold (0.00 log units) above; measured number inside the range.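

In this assay, within the data shown here, the 3,5-dimethoxyphenyl group on this carbonyl carbon gives a second exact number, which allows the first comparison between two measured values: a 1.3-fold higher number from compound 2 to compound 4 (0.12 log units; within the scatter) and so no real separation from 4-methoxyphenyl. Against the two compounds held at a limit, only floors can be read: an at least 1.1-fold lower number from compound 3 to compound 4 (0.07 log units; that floor lies within the scatter) and an at least 1.1-fold lower number from compound 1 to compound 4 (0.07 log units; that floor lies within the scatter) and neither floor clears the scatter. Exact numbers remain scarce in this small set: the limit of > 100000 nM in this assay, at which 2 of the 4 values shown sit.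

As far as these compounds go, whether an amine or a carboxylic acid on this aromatic ring, in place of methoxy, would move the number beyond the scatter stays open.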